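Amine-nitrogen substituent swaps on a shared dihydropyridine-like core

A few compounds are considered here, and "the series" means these few. Any claim that something is new, unique, unknown or untested is made for them only; others in the source may bear on it.

In a functional assay on HepG2 cells (Homo sapiens) for inhibition, read by MTT assay, with a stated time of 48 h (a higher number here means a weaker inhibitor, a lower number a stronger inhibitor), the measured compounds stand as follows:
compound 1 `CCOC(=O)C1=C(N/C=N/c2cccnc2Cl)Nc2[nH]nc(C)c2C1c1ccc(N(C)C)cc1` gives 4890 nM
compound 2 `CCOC(=O)C1=C(N/C=N/c2nnc(S(N)(=O)=O)s2)Nc2[nH]nc(C)c2C1c1ccc(N(C)C)cc1` gives 38100 nM
compound 3 `CCOC(=O)C1=C(N/N=C(\C#N)C(N)=O)Nc2[nH]nc(C)c2C1c1ccc(N(C)C)cc1` gives 48400 nM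

Compound 2 holds the second highest of the three numbers; its gap to compound 3 lies within the scatter, and the step of a 7.8-fold higher number from compound 1 to compound 2 (0.89 log units; beyond the scatter) is beyond it. Compound 4 `CCOC(=O)C1=C(N/N=C(/Cl)C#N)Nc2[nH]nc(C)c2C1c1ccc(N(C)C)cc1` carries a group of 5 heavy atoms (2 carbon, 2 nitrogen, 1 chlorine; no ring) in place of a group of 11 heavy atoms (3 carbon, 4 nitrogen, 2 oxygen, 2 sulfur; one five-membered aromatic ring with 3 hetero atoms), on an amine nitrogen. Among the compounds with values here, the steps that bear on this are a 7.8-fold higher number from compound 1 to compound 2 (0.89 log units; beyond the scatter) and a 9.9-fold higher number from compound 1 to compound 3 (1.00 log units; beyond the scatter), both modest rises on leaving the 2-chloropyridin-3-yl, and a 1.3-fold higher number from compound 2 to compound 3 (0.10 log units; within the scatter), which stayed within the scatter when an acyclic group replaced the thiadiazole. Since the entering group of compound 4 is likewise acyclic, the expected step of a 1.0-fold higher number from compound 2 to compound 4 (0.02 log units; within the scatter) is none beyond the scatter. Compound 4 is estimated at 40000 nM, within 12000 nM to 130000 nM.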

Compound 4, half-maximal inhibitory concentration: 23600 nM
Beside the measured number, compound 4's estimate is 1.7-fold (0.23 log units) above it; measured number inside the range.
By their numbers in this assay, from the lowest: compound 1; then compounds 4, 2 and 3 (each within the scatter of the next, the first and the last beyond it).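

In this assay, chloro in place of carbamoyl on the carbon with a double bond to nitrogen gives a 2.1-fold lower number from compound 3 to compound 4 (0.31 log units; beyond the scatter), so a change within the acyclic group on the amine nitrogen can register, though modestly. The smaller acyclic group of compound 4 matches the 5-sulfamoyl-1,3,4-thiadiazol-2-yl group of compound 2, with a 1.6-fold lower number from compound 2 to compound 4 (0.21 log units; within the scatter), while a 4.8-fold higher number from compound 1 to compound 4 (0.68 log units; beyond the scatter) leaves compound 1 with the lowest number. No measured evidence here explains these steps.

From the compounds shown here alone, whether a methyl or a carboxylic acid on that same carbon would follow chloro or carbamoyl remains open. So does whether any acyclic group can reach the number of compound 1.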